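The source may report more compounds than this note shows. Statements on the series, on what has been measured and on what is new or still open speak of the compounds shown alone.

Values in a functional assay on PC-3 cells (Homo sapiens) for cytotoxicity, read by MTT assay, with a stated time of 96 h; on this read-out lower numbers stand for stronger inhibition and higher numbers for weaker inhibition:
- Compound 1 `CC[C@H](N)C(=O)N[C@@H]1C(=O)N2[C@@H](CC[C@@H]1CCN)CC[C@H]2C(=O)NC(c1ccccc1)c1ccccc1`: 85200 nM
- Compound 2 `CC[C@H](N)C(=O)N[C@@H]1C(=O)N2[C@@H](CC[C@@H]1CCNC(=O)c1ccccc1)CC[C@H]2C(=O)NC(c1ccccc1)c1ccccc1`: > 100000 nM (a limit)
- Compound 3 `CC[C@H](NC)C(=O)N[C@@H]1C(=O)N2[C@@H](CC[C@@H]1CCNC(=O)c1ccccc1)CC[C@H]2C(=O)NC(c1ccccc1)c1ccccc1`: > 100000 nM (a limit)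

Compound 2 has no exact number, only the limit > 100000 nM. This is a common result in the series: the limit of > 100000 nM in this assay, at which 2 of the 3 values shown sit.

Compound 4 `CCNCC[C@H]1CC[C@H]2CC[C@@H](C(=O)NC(c3ccccc3)c3ccccc3)N2C(=O)[C@H]1NC(=O)[C@@H](N)CC` is not yet measured. It has ethyl in place of benzoyl on an amine nitrogen.

The closest measured step is an at least 1.1-fold higher number from compound 1 to compound 2 (0.06 log units; that floor lies within the scatter), which places benzoyl on that same amine nitrogen. It shows no change beyond the scatter. The other step, a step that the two limits leave unreadable from compound 2 to compound 3, concerns a different amine nitrogen and cannot be read, so it offers no guide.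

Compound 4 lacks benzoyl, and compound 1, which also lacks it, gives 85200 nM. In this assay, only a small move toward lower numbers is therefore expected, and it may not exceed the scatter: an at least 1.2-fold lower number from compound 2 to compound 4 (0.09 log units; that floor lies within the scatter). The estimated value for compound 4 is 80000 nM, with an expected range of 30000 nM to 100000 nM.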

Compound 4, half-maximal inhibitory concentration: > 100000 nM
Compound 4 ended at the assay's limit; the forecaster's own chance of this, stated with the estimate: 45%; middle value at least 1.2-fold (0.09 log units) from the limit.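

In this assay compound 4 gives > 100000 nM, a limit and not a number, and it joins the most common result in the series: the limit of > 100000 nM in this assay, at which 3 of the 4 values shown sit.

Ethyl in place of hydrogen on this amine nitrogen gives an at least 1.1-fold higher number from compound 1 to compound 4 (0.06 log units; that floor lies within the scatter). So a simple chain without a ring, like the benzoyl group before it, shows no change beyond the scatter, although each step is only a floor and the true size could be larger; the steps between limits cannot be read.

Going by these compounds, whether any group on this nitrogen can bring the value clearly below that of compound 1, at 85200 nM, stays open. An acetyl group, a longer chain such as butyl, or a chain ending in a carboxylic acid would each test this.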